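From a Pyrrolidine Ring to an Open Aminoethyl Chain

This account rests on a few compounds, and the source may have more. Where it says the series, first, only, none or still open, it means among the compounds named here.

Compound 3 `COc1cc(C(=O)c2ccc(-c3csc(NC(=O)[C@@H]4CCCN4)n3)cc2-n2cncn2)cc(OC)c1OC` carries a pyrrolidin-2-yl group on its amide carbonyl carbon. In a functional assay on HL-60 cells (Homo sapiens) for antiproliferative activity, read by MTT assay, with a stated time of 72 h (on this read-out higher numbers stand for weaker inhibition and lower numbers for stronger inhibition), compound 3 gives 98 nM, the second highest of three numbers: compound 2 `COc1cc(C(=O)c2ccc(-c3csc(NC(=O)[C@@H](N)C(C)C)n3)cc2-n2cncn2)cc(OC)c1OC` gives 110 nM, within the scatter of compound 3, while compound 1 `COc1cc(C(=O)c2ccc(-c3csc(NC(=O)CN)n3)cc2-n2cncn2)cc(OC)c1OC` gives 27 nM. Compound 4 `COc1cc(C(=O)c2ccc(-c3csc(NC(=O)[C@H](C)N)n3)cc2-n2cncn2)cc(OC)c1OC` differs from compound 3 in one place: 1-aminoethyl in place of pyrrolidin-2-yl on a carbonyl carbon. Going by the values given here, two steps bear on this. Replacing the aminomethyl of compound 1 by larger groups raised the number: a 4.1-fold higher number from compound 1 to compound 2 (0.61 log units; beyond the scatter) and a 3.6-fold higher number from compound 1 to compound 3 (0.56 log units; beyond the scatter). Between those larger groups, a 1.1-fold lower number from compound 2 to compound 3 (0.05 log units; within the scatter). Since 1-aminoethyl resembles the aminomethyl of compound 1 more than the pyrrolidin-2-yl of compound 3, a modest step toward the number of compound 1 is expected, a 2.0-fold lower number from compound 3 to compound 4 (0.29 log units; within the scatter). Compound 4 is therefore estimated at 50 nM, within a range from 20 nM to 130 nM.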

Compound 4, half-maximal inhibitory concentration: 13 nM
Compound 4: the middle estimate sits 3.8-fold (0.59 log units) above what was measured, and the stated range ends above it.
By their numbers in this assay, from the lowest: compound 4; then compound 1; then compounds 3 and 2 (each within the scatter of the next).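

On the carbon bound to the amine nitrogen and the carbonyl carbon, adding a single methyl to compound 1 lowers the number further (a 2.1-fold lower number from compound 1 to compound 4 (0.32 log units; beyond the scatter)), so hydrogen is not the best group seen at this position. Larger groups go the other way: methyl in place of isopropyl gives an 8.5-fold lower number from compound 2 to compound 4 (0.93 log units; beyond the scatter), and 1-aminoethyl in place of pyrrolidin-2-yl gives a 7.5-fold lower number from compound 3 to compound 4 (0.88 log units; beyond the scatter), so the number does not move in one direction as the group grows. No measurement shown here explains this turn. From the compounds shown here alone, what an ethyl group on that carbon would give remains open, as does the effect of the mirror-image 1-aminoethyl group.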